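From methylsulfanyl to dimethylamino in the thiophen-3-yl series

The compounds below may be only part of what the source reports. "The series", "measured", "known", "first", "only" and "open" are said of these compounds alone.

Values in a functional assay on HeLa S3 cells (Homo sapiens) for antiproliferative activity, read by XTT assay, with a stated time of 72 h (a lower number here means a stronger inhibitor, a higher number a weaker inhibitor), follow.

Compound 1 `CSc1ncnc2c1c(-c1cccs1)cn2[C@@H]1O[C@H](CO)[C@@H](O)[C@H]1O` gives 1960 nM as a number
Compound 2 `CSc1ncnc2c1c(-c1ccsc1)cn2[C@@H]1O[C@H](CO)[C@@H](O)[C@H]1O` gives > 20000 nM as a limit
Compound 3 `CSc1ncnc2c1c(-c1ccccc1)cn2[C@@H]1O[C@H](CO)[C@@H](O)[C@H]1O` gives > 20000 nM as a limit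

Compound 2 has no number, only the limit > 20000 nM in this assay. It sits at the limit of > 20000 nM in this assay, at which 2 of the 3 values shown sit, and can be placed no more closely.

Compound 4 `CN(C)c1ncnc2c1c(-c1ccsc1)cn2[C@@H]1O[C@H](CO)[C@@H](O)[C@H]1O` keeps the thiophen-3-yl group of compound 2 and carries dimethylamino in place of methylsulfanyl on an aromatic carbon. Within the data shown here, no measured step makes this exchange. The nearest evidence concerns the aromatic group instead: an at least 10-fold higher number from compound 1 to compound 2 (1.00 log units; beyond the scatter) and an at least 10-fold higher number from compound 1 to compound 3 (1.00 log units; beyond the scatter), both beyond the scatter, while a step that the two limits leave unreadable from compound 2 to compound 3 cannot be read. Among these three compounds, only the thiophen-2-yl group gives a number.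

The expectation rests on an at least 10-fold higher number from compound 1 to compound 2 (1.00 log units; beyond the scatter). Compound 4 retains the thiophen-3-yl group, so it is expected to stay weak, most likely at the same limit, with no readable step beyond the scatter. The expected step is a number no higher from compound 2 to compound 4 (the limit leaves the size open). For compound 4 the estimated value is 20000 nM, with an expected range from 6000 nM to 40000 nM.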

Compound 4, half-maximal inhibitory concentration: > 15000 nM
Compound 4: only a limit was reported; the forecaster's own chance of this, stated with the estimate: 75%; the middle value lies beyond the limit too.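

Compound 2 and compound 4 are both known only as limits in this assay, and the step between them, dimethylamino in place of methylsulfanyl, cannot be read. The compounds shown leave open what this exchange does to the antiproliferative read-out, both with the thiophen-3-yl group and with the thiophen-2-yl group of compound 1, which alone gives a number.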